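A few compounds are considered here, and "the series" means these few. Any claim that something is new, unique, unknown or untested is made for them only; others in the source may bear on it.

Compound 3 `Fc1cccc(-c2nn3c(Cc4ccccc4F)nnc3s2)c1` gives 25% in an assay for inhibition of histone-lysine N-methyltransferase, H3 lysine-79 specific (Homo sapiens), with stated times of 15 min and 120 min, tested at 50 uM; on this read-out higher numbers stand for more inhibition at the one concentration tested (going by the name of the read-out) and lower numbers for less inhibition. It stands second highest of the three numbers shown: compound 1 `Fc1cccc(-c2nn3c(Cc4ccccc4)nnc3s2)c1` gives 33%, a difference of a number 8 percentage points lower from compound 1 to compound 3 (within the scatter), while compound 2 `CCc1nnc2sc(-c3cccc(F)c3)nn12` gives 13%, a difference of a number 12 percentage points higher from compound 2 to compound 3 (beyond the scatter). Compound 4 `Fc1cccc(-c2nn3c(CN4CCCCC4)nnc3s2)c1` has not yet been measured; it differs from compound 3 by piperidin-1-yl in place of 2-fluorophenyl on a saturated chain carbon bound to an aromatic carbon. Within the data shown here, two measured steps touch the same saturated chain carbon: a number 20 percentage points lower from compound 1 to compound 2 (beyond the scatter) and a number 12 percentage points higher from compound 2 to compound 3 (beyond the scatter), and both show that a six-membered aromatic ring on that carbon goes with a higher number than a methyl does. Piperidin-1-yl is a six-membered non-aromatic ring with one hetero atom, so no measured step matches it directly; a modest fall toward the number of compound 2 seems the likelier outcome, though a step within the scatter cannot be excluded. Compound 4 is therefore expected to show a number 7 percentage points lower from compound 3 to compound 4 (within the scatter), giving an estimate of 18%, within a range from 5% to 33%.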

Compound 4, a percentage reported as inhibition, at one concentration (the size of the read-out at that concentration, not a potency): 6%
For compound 4 the middle estimate is 12 percentage points above the measured one; the range from low to high includes it.
By their numbers in this assay, from the lowest: compounds 4 and 2 (each within the scatter of the next); then compounds 3 and 1 (each within the scatter of the next).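

Among these compounds, at the saturated chain carbon bound to an aromatic carbon, the earlier compounds linked a six-membered aromatic ring to a higher number than methyl, and compound 4 shows that a six-membered ring alone does not bring this in this assay. Piperidin-1-yl gives a number 19 percentage points lower from compound 3 to compound 4 (beyond the scatter) and a number 27 percentage points lower from compound 1 to compound 4 (beyond the scatter), whereas the comparison with methyl gives a number 7 percentage points lower from compound 2 to compound 4 (within the scatter) and so separates neither group from the other. No measurement shown explains why the non-aromatic ring reads so differently from the aromatic ones.

Piperidin-1-yl differs from the aromatic rings both in being non-aromatic and in holding a ring nitrogen, and the compounds shown do not tell which difference goes with the lower number. Cyclohexyl, a carbon-only non-aromatic ring, and pyridinyl, an aromatic ring holding nitrogen, would separate these two differences at this position.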